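Vero cell tolerance across a four-compound amide series

The compounds below may be only part of what the source reports. "The series", "measured", "known", "first", "only" and "open" are said of these compounds alone.

Compound 1 `COC(=O)CCCNC(=O)c1cccc2c1NCCC2` and compound 2 `COC(=O)/C=C/CNC(=O)c1cccc2c1NCCC2` share one core; compound 3 `COC(=O)/C=C/CNC(=O)c1cccc2c1NC(C)(C)C=C2C` and compound 4 `COC(=O)CCCNC(=O)c1cccc2c1NC(C)(C)C=C2C` share another, and the difference between the two cores is not broken down here. In an ADME assay on Vero C1008 cells (Chlorocebus sabaeus) for cytotoxicity (a lower number here means that less compound is tolerated, a higher number that more compound is tolerated), compound 1 gives only a limit, > 30000 nM. In this assay compound 2 likewise gives a limit, > 30000 nM. Hence a step that the two limits leave unreadable from compound 2 to compound 1, the change being (2-(methoxycarbonyl)ethyl in place of 2-(methoxycarbonyl)ethenyl on a saturated chain carbon bound to an amide-type nitrogen). Within the data shown here, compound 3 gives 6700 nM in this assay, the only number among the three values; the others sit at the limit of > 30000 nM in this assay, at which 2 of the 3 values shown sit. The same change recurs as 2-(methoxycarbonyl)ethyl in place of 2-(methoxycarbonyl)ethenyl on a saturated chain carbon bound to an amide-type nitrogen, with the place described in identical words. Because the measured pair reads as a step that the two limits leave unreadable from compound 2 to compound 1, the expected size of the step rests on nothing beyond that pair and is estimated as a 1.0-fold higher number from compound 3 to compound 4 (0.02 log units; within the scatter). Compound 4 is accordingly estimated at 7000 nM, expected between 3000 nM and 20000 nM.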

Compound 4, half-maximal cytotoxic concentration: > 30000 nM
Compound 4: no number, only a limit; the forecaster's own chance of this, stated with the estimate: 20%; at least 4.2-fold (0.63 log units) between middle value and limit.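

On these data alone, on the second core, 2-(methoxycarbonyl)ethyl in place of 2-(methoxycarbonyl)ethenyl gives in this assay an at least 4.4-fold higher number from compound 3 to compound 4 (0.65 log units; beyond the scatter), and the full size of this step stays unknown, as one end of it is a limit. Among these compounds, on the first core, the same change cannot be read, as both ends are limits, so the series does not show that the step carries from one core to the other, only that the two readings do not conflict. The whole comparison rests on a single limit: the limit of > 30000 nM in this assay, at which 3 of the 4 values shown sit.

As far as these compounds go, it remains open how a carboxylic acid in place of the methyl ester, or a longer chain, would read in this assay. From the compounds shown here alone, it also remains open what size the step would take on the first core.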